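Chloro for methyl beside the thiazolidinedione methylene

The source may report more compounds than this note shows. Statements on the series, on what has been measured and on what is new or still open speak of the compounds shown alone.

Compound 1 `Cc1cc(Oc2ncc(C(F)(F)F)cc2Cl)ccc1CC1SC(=O)NC1=O` is the most potent of the three measured compounds in a functional assay for agonist activity at Free fatty acid receptor 1 (Homo sapiens), read by FLIPR, in the presence of a further agent that is not named here (a higher number here means that more compound is needed for the effect, a lower number that less compound is needed), where compound 1 gives 10 nM. The nearest measured compound is compound 3 `Cc1cc(Oc2ncc(C(F)(F)F)cc2Cl)cc(C)c1CC1SC(=O)NC1=O`, which gives 5450 nM; the step of a 550-fold higher number from compound 1 to compound 3 (2.74 log units; beyond the scatter) shows how sharply the number rises when a methyl is added. Furthest away is compound 2 `O=C1NC(=O)C(Cc2ccccc2Oc2ccccc2)S1`, a compound that carries neither the substituted pyridyloxy group nor the ring methyl, and gives 11300 nM.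

The unmeasured compound 4 `O=C1NC(=O)C(Cc2ccc(Oc3ncc(C(F)(F)F)cc3Cl)cc2Cl)S1` differs from compound 1 in a single place: chloro in place of methyl on an aromatic carbon. No measured step exchanges methyl for chloro; the one step shown, from compound 1 to compound 3, adds a methyl at a different position and was large, and the gap from compound 1 to compound 2 involves several changes at once, so neither bears directly on this swap. With a single-atom exchange at the same position and no contrary evidence, the expected step in this assay is small, and may not exceed the scatter, with a slight lean toward a higher number. Compound 4 is therefore estimated at 20 nM in this assay, within a range from 5 nM to 100 nM, which corresponds to an expected step of a 2.0-fold higher number from compound 1 to compound 4 (0.30 log units; within the scatter).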

Compound 4, half-maximal effective concentration: 26 nM
Compound 4: middle estimate off by 1.3-fold (0.11 log units), on the low side; the range from low to high includes it.
By their numbers in this assay, from the lowest: compound 1; then compound 4; then compound 3; then compound 2.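

In this assay, the position ortho to a (2,4-dioxo-1,3-thiazolidin-5-yl)methyl group accepts chloro in place of methyl at a modest cost: the number rises by a 2.6-fold higher number from compound 1 to compound 4 (0.41 log units; beyond the scatter), a real change but one that leaves compound 4 in the same low range as compound 1. The earlier step, a 550-fold higher number from compound 1 to compound 3 (2.74 log units; beyond the scatter), came from adding a methyl at a different position on the same ring, and the new step is far smaller, so within these compounds the two changes to this ring do not weigh alike. Nothing available on these compounds gives a reason for the difference between methyl and chloro at this position.

With only methyl and chloro compared here, the compounds shown leave open whether fluoro, methoxy, a nitrile or plain hydrogen at this position would give a number nearer to that of compound 1 or to that of compound 4. They also leave open whether the same exchange would have a similar effect if the substituted pyridyloxy group gave way to another group, such as an amine or a carboxylic acid.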